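Quinoxaline-type diamine series: thioether analogue of compound 1

The source may report more compounds than this note shows. Statements on the series, on what has been measured and on what is new or still open speak of the compounds shown alone.

Compound 1 `Nc1cc(N)c2nc(-c3ccccc3)c(Oc3ccc(Cl)c(Cl)c3)nc2c1` is known in a functional assay on CAKI-1 cells (Homo sapiens) for inhibition, read by sulforhodamine B assay, with a stated time of 48 h (on this read-out lower numbers stand for higher toxicity in this test and higher numbers for lower toxicity in this test), only as a limit, giving < 100000 nM. Compound 2 `COc1ccc(CNc2nc3cc(N)cc(N)c3nc2-c2ccccc2)cc1` differs from compound 1 in more than one place. In this assay compound 2 gives a value of 79400 nM. For the measured compounds named here, no single-point step between measured compounds exists in this set, so the only anchor for compound 1 is the limit itself (the limit of < 100000 nM in this assay, at which 1 of the 2 values shown sits).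

Compound 3 `Nc1cc(N)c2nc(-c3ccccc3)c(Sc3ccc(F)cc3)nc2c1` is not yet measured in this assay. It differs from compound 1 by (4-fluorophenyl)sulfanyl in place of 3,4-dichlorophenoxy on an aromatic carbon. Going by the values given here, no step of this kind has been measured, so the size of the change from the exchange of the 3,4-dichlorophenoxy group for the (4-fluorophenyl)sulfanyl group cannot be read from any neighbour.

Both numbers shown sit in the weak range of this assay, and the expectation for compound 3 is a step of no clear direction beyond the scatter, a step that the limit leaves unreadable from compound 1 to compound 3. The estimate for compound 3 in this assay is 60000 nM, within a range from 15000 nM to 100000 nM, with a substantial chance that only a limit is reported.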

Compound 3, concentration lethal to 50% of the cells: < 100000 nM
Compound 3: a limit, no number (the forecaster's own chance of this, stated with the estimate: 50%); the middle value lies beyond the limit too.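

Compound 1 and compound 3 are both known only as limits, so no step between them can be read: the limit of < 100000 nM in this assay, at which 2 of the 3 values shown sit.

The compounds shown leave open whether (4-fluorophenyl)sulfanyl in place of 3,4-dichlorophenoxy on the shared core changes the read-out in this assay at all, and in which direction.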